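This account rests on a few compounds, and the source may have more. Where it says the series, first, only, none or still open, it means among the compounds named here.

Measured compounds in a functional assay on PANC-1 cells (Homo sapiens) for inhibition, read by MTT assay, with a stated time of 72 h; a higher number here means a weaker inhibitor of growth, a lower number a stronger inhibitor of growth:
compound 1 `O=S(=O)(NCCCNCc1ccc(Cl)cc1)c1cc(C(F)(F)F)cc(C(F)(F)F)c1` gives 4900 nM
compound 2 `COc1ccc(CNCCCNS(=O)(=O)c2cc(C(F)(F)F)cc(C(F)(F)F)c2)cc1OC` gives 18000 nM
compound 3 `COc1cccc(CNCCCNS(=O)(=O)c2cc(C(F)(F)F)cc(C(F)(F)F)c2)c1` gives 10000 nM

Compound 3 stands second highest of the three numbers. Its nearest neighbour is compound 2, separated by a 1.8-fold lower number from compound 2 to compound 3 (0.26 log units; within the scatter), which is within the scatter, so no order between compound 2 and compound 3 can be read. The step from compound 1 is a 2.0-fold higher number from compound 1 to compound 3 (0.31 log units; beyond the scatter), beyond the scatter, so compound 3 sits clearly above compound 1.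

Compound 4 `O=S(=O)(NCCCNCc1ccc(C(F)(F)F)cc1)c1cc(C(F)(F)F)cc(C(F)(F)F)c1` is not yet measured. It differs from compound 3 as follows: 4-(trifluoromethyl)phenyl in place of 3-methoxyphenyl on a saturated chain carbon bound to an amine nitrogen.

For the measured compounds named here, two measured steps bear on this. a 2.0-fold higher number from compound 1 to compound 3 (0.31 log units; beyond the scatter) shows that 3-methoxyphenyl in place of 4-chlorophenyl raised the number modestly; a 3.7-fold higher number from compound 1 to compound 2 (0.57 log units; beyond the scatter) shows that 3,4-dimethoxyphenyl raised it somewhat more. Both methoxy-bearing compounds gave higher numbers than compound 1. Compound 4 brings in 4-(trifluoromethyl)phenyl, which, like the 4-chlorophenyl of compound 1, carries no hydrogen-bond acceptor. Going by the values given here, no measured compound carries trifluoromethylphenyl at this place, so the expectation rests on compound 1 alone. The step is expected to be a modest lowering, a 1.8-fold lower number from compound 3 to compound 4 (0.26 log units; within the scatter), returning compound 4 roughly to where compound 1 stands. Compound 4 is therefore estimated at 5500 nM, with a range from 2500 nM to 12000 nM.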

Compound 4, concentration for 50% growth inhibition: 3200 nM
Beside the measured number, compound 4's estimate is 1.7-fold (0.24 log units) above it; measured number inside the range.
By their numbers in this assay, from the lowest: compounds 4 and 1 (each within the scatter of the next); then compounds 3 and 2 (each within the scatter of the next).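

In (this assay), 4-(trifluoromethyl)phenyl on a saturated chain carbon bound to an amine nitrogen gives a clear shift against both methoxy-bearing groups (a 3.1-fold lower number from compound 3 to compound 4 (0.49 log units; beyond the scatter)) and (a 5.6-fold lower number from compound 2 to compound 4 (0.75 log units; beyond the scatter)). Trifluoromethyl in place of chloro on an aromatic carbon stays within the scatter (a 1.5-fold lower number from compound 1 to compound 4 (0.19 log units; within the scatter)), so this place tolerates that exchange without a readable change in this assay, and compound 4 joins compound 1 as a second methoxy-free member with a lower number than compound 2 and compound 3, with no exception among these four compounds. No measurement shown accounts for this separation.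

The compounds shown do not separate the presence of methoxy from where it sits on the ring, so it remains unclear whether the group itself or its placement goes with the higher numbers. Also open, from the compounds shown here alone, is how an unsubstituted phenyl, a phenyl bearing a nitrile, a pyridine ring or a longer chain on the shared core would stand against compound 4 and compound 1 in this growth read-out.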